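Cyclohexyl to isopropyl swap across two amine cores

The source may report more compounds than this note shows. Statements on the series, on what has been measured and on what is new or still open speak of the compounds shown alone.

Of the compounds shown here, three have been measured in a physicochemical assay for acid dissociation. Compound 1 `CC(C)Cc1ccc2c(NCCCNCc3ccco3)ccnc2c1` gives 9.47, compound 2 `c1coc(CNCCCNc2ccnc3cc(CC4CCCCC4)ccc23)c1` gives 9.47 and compound 3 `COc1ccc(F)cc1CNCCCNc1ccnc2cc(CC3CCCCC3)ccc12` gives 9.47. Compound 1 and compound 2 differ by isopropyl in place of cyclohexyl on a saturated chain carbon bound to an aromatic carbon, and this step reads no change at the digits printed from compound 2 to compound 1 (within the scatter). The cores of compound 2 and compound 3 differ by 5-fluoro-2-methoxyphenyl in place of furan-2-yl on a saturated chain carbon bound to an amine nitrogen, with a step of no change at the digits printed from compound 2 to compound 3 (within the scatter). Compound 4 `COc1ccc(F)cc1CNCCCNc1ccnc2cc(CC(C)C)ccc12` has not yet been measured. It differs from compound 3 by isopropyl in place of cyclohexyl on a saturated chain carbon bound to an aromatic carbon, the same change as from compound 2 to compound 1, made at the same place. The expected step from compound 3 to compound 4 is no change at the digits printed from compound 3 to compound 4 (within the scatter), resting on the earlier step of no change at the digits printed from compound 2 to compound 1 (within the scatter) between compound 2 and compound 1. Compound 4 is expected to give 9.47 in this assay, with an estimated range from 9.17 to 9.77.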

Compound 4, acid dissociation constant: 9.47
Estimate against measurement, compound 4: no gap at the digits printed; the range from low to high includes it.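

In this assay, isopropyl in place of cyclohexyl reads no change at the digits printed from compound 3 to compound 4 (within the scatter) and so agrees with no change at the digits printed from compound 2 to compound 1 (within the scatter) on the other amine, while 5-fluoro-2-methoxyphenyl in place of furan-2-yl reads no change at the digits printed from compound 1 to compound 4 (within the scatter) and agrees with no change at the digits printed from compound 2 to compound 3 (within the scatter) on the other side chain. Going by these compounds alone, this shows the cyclohexyl to isopropyl change carrying from one core to the other without a step in either case, but with no step of measurable size in the set, it does not show that a larger step would carry in the same way. No measurement bearing on why the values coincide is available.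

Still open, as far as these compounds go, is whether an amine or a carboxylic acid in place of isopropyl, on a saturated chain carbon bound to an aromatic carbon, would keep the read-out level. From the compounds shown here alone, a longer chain in place of cyclohexylmethyl or isobutyl is equally open.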